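Exchanging dimethylamino for pyrrolidin-1-yl on the shared core

This account rests on a few compounds, and the source may have more. Where it says the series, first, only, none or still open, it means among the compounds named here.

In an ADME assay on L6 cells (Rattus norvegicus) for cytotoxicity (on this read-out higher numbers stand for weaker inhibition and lower numbers for stronger inhibition), compound 1 (`O=C(CN1CCCC1)OC1CC2(N3CCCC3)CC(c3ccccc3)C1C(c1ccccc1)C2`) gives 42900 nM, compound 2 (`O=C(CCN1CCCC1)OC1CC2(N3CCCC3)CC(c3ccccc3)C1C(c1ccccc1)C2`) gives 21900 nM, and compound 3 (`CN(C)C12CC(OC(=O)CCN3CCC(O)CC3)C(C(c3ccccc3)C1)C(c1ccccc1)C2`) gives 89200 nM, the highest of the three numbers and beyond the scatter from both others. Compound 4 (`O=C(CCN1CCC(O)CC1)OC1CC2(N3CCCC3)CC(c3ccccc3)C1C(c1ccccc1)C2`) keeps the side chain of compound 3 and changes only on a saturated ring carbon: pyrrolidin-1-yl in place of dimethylamino on a saturated ring carbon. Among the compounds with values here, no measured step covers this exchange. Within the data shown here, the one available step, a 2.0-fold lower number from compound 1 to compound 2 (0.29 log units; within the scatter), concerns the side chain and bears on it only indirectly. Compound 1 and compound 2 both carry pyrrolidin-1-yl at that carbon, but they also differ from compound 3 at the chain end. A modest move to a lower number is therefore expected, estimated as a 2.2-fold lower number from compound 3 to compound 4 (0.35 log units; beyond the scatter). Compound 4 is estimated at 40000 nM, with an expected range of 16000 nM to 90000 nM.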

Compound 4, half-maximal inhibitory concentration: 35600 nM
Beside the measured number, compound 4's estimate is 1.1-fold (0.05 log units) above it, within the range that was stated.
By their numbers in this assay, from the lowest: compounds 2, 4 and 1 (each within the scatter of the next); then compound 3.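

In this assay, the exchange on the saturated ring carbon now has a direct measure: pyrrolidin-1-yl in place of dimethylamino gives a step beyond the scatter (a 2.5-fold lower number from compound 3 to compound 4 (0.40 log units; beyond the scatter)). With pyrrolidin-1-yl on that carbon, the chain end separates none of the three compounds, either for 4-hydroxypiperidin-1-yl in place of pyrrolidin-1-yl (a 1.6-fold higher number from compound 2 to compound 4 (0.21 log units; within the scatter)) or for (4-hydroxypiperidin-1-yl)methyl in place of pyrrolidin-1-yl (a 1.2-fold lower number from compound 1 to compound 4 (0.08 log units; within the scatter)). Nothing available accounts for the ring-carbon step.

Open, going by these compounds, is whether that step holds with any other chain end, such as pyrrolidin-1-yl. Also open, on these data alone, is the outcome for diethylamino or piperidin-1-yl on the same ring carbon.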